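The source may hold more compounds than are shown below. What is called first, only, known or untested is meant among the compounds shown, and "the series" means these compounds.

In an assay on HEK293 cells for displacement of a labelled ligand from Melanocortin receptor 4 (Homo sapiens) (a higher number here means a weaker inhibitor, a lower number a stronger inhibitor), compound 3 `CC(C)C[C@H](N)c1cc(C(F)(F)F)ccc1N1CCN(C(=O)C(C)Cc2ccc(Cl)cc2)CC1` gives 47 nM, the lowest number among the three measured compounds. Its nearest neighbour is compound 1 `CC(C)C[C@H](N)c1cc(C(F)(F)F)ccc1N1CCN(C(=O)COc2cccc(Cl)c2Cl)CC1`, which in this assay gives 2500 nM, so that the step of a 53-fold lower number from compound 1 to compound 3 (1.73 log units; beyond the scatter) was large. Compound 2 `CC(C)C[C@H](N)c1cc(C(F)(F)F)ccc1N1CCN(C(=O)CCC(N)=O)CC1` reaches only (the limit of > 10000 nM in this assay, at which 1 of the 3 values shown sits), reported as > 10000 nM. Compound 4 `CC(C)C[C@H](N)c1cc(C(F)(F)F)ccc1N1CCN(C(=O)COc2ccc(Cl)cc2)CC1` has not yet been measured; it differs from compound 3 by (4-chlorophenoxy)methyl in place of 1-(4-chlorobenzyl)ethyl on a carbonyl carbon. This change largely undoes the step of a 53-fold lower number from compound 1 to compound 3 (1.73 log units; beyond the scatter), since compound 4 carries an aryloxymethyl group resembling that of compound 1, so a large rise in this assay number is expected from compound 3 to compound 4, though the (4-chlorophenoxy)methyl of compound 4 is not the 2,3-dichlorophenoxy group of compound 1. Compound 4 is therefore estimated at 1500 nM, between 400 nM and 6000 nM, an expected step of a 32-fold higher number from compound 3 to compound 4 (1.50 log units; beyond the scatter).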

Compound 4, inhibition constant: 2900 nM
Compound 4: middle estimate off by 1.9-fold (0.29 log units), on the low side; measured number inside the range.
By their numbers in this assay, from the lowest: compound 3; then compounds 1 and 4 (each within the scatter of the next). At a limit, above all of these: compound 2.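

In this assay the loss on leaving 1-(4-chlorobenzyl)ethyl for a phenoxymethyl-type group recurs with (4-chlorophenoxy)methyl (a 62-fold higher number from compound 3 to compound 4 (1.79 log units; beyond the scatter)), so it does not depend on the 2,3-dichlorophenoxy group alone. The 4-chlorophenyl and 2,3-dichlorophenyl groups on the oxygen cannot be told apart here (a 1.2-fold higher number from compound 1 to compound 4 (0.06 log units; within the scatter)). Compound 4 also stands clear of compound 2 (an at least 3.4-fold lower number from compound 2 to compound 4 (0.53 log units; beyond the scatter)), a step read against a limit: the limit of > 10000 nM in this assay, at which 1 of the 4 values shown sits.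

Open, from the compounds shown here alone, is whether the gain of compound 3 comes from the methyl branch or from the absence of the ether oxygen. An unbranched 2-(4-chlorophenyl)ethyl group on the carbonyl carbon would separate the two.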